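Anilide series on one core: hydroxy to trifluoromethyl

The source may hold more compounds than are shown below. What is called first, only, known or untested is meant among the compounds shown, and "the series" means these compounds.

Compound 3 `O=C(Nc1ccc(O)cc1)C1NCCc2ccccc21` and compound 2 `O=C(Nc1ccc(C(F)(F)F)cc1)C1NCCc2ccccc21` share one core. In a functional assay on NUGC-3 cells (Homo sapiens) for inhibition, read by sulforhodamine B assay, with a stated time of 48 h (a higher number here means a weaker inhibitor of growth, a lower number a stronger inhibitor of growth), compound 3 gives 4370 nM. In this assay compound 2 gives 4220 nM. The change trifluoromethyl in place of hydroxy on an aromatic carbon made the step of a 1.0-fold lower number from compound 3 to compound 2 (0.02 log units; within the scatter). Compound 1 `O=C(Nc1cccc(O)c1)C1NCCc2ccccc21` holds the same atoms as compound 3, joined differently; the difference between the two cores is not broken down here. In this assay compound 1 reaches only the limit > 10000 nM. That is the limit of > 10000 nM in this assay, at which 1 of the 3 values shown sits. Compound 4 `O=C(Nc1cccc(C(F)(F)F)c1)C1NCCc2ccccc21` is not yet measured. The change trifluoromethyl in place of hydroxy on an aromatic carbon is the same kind of change as that from compound 3 to compound 2, but the place differs: para to a large group in the one, meta to a large group in the other. Because a 1.0-fold lower number from compound 3 to compound 2 (0.02 log units; within the scatter) lay within the scatter, the step is expected to be a step that the limit leaves unreadable from compound 1 to compound 4. Compound 4 is expected at 12000 nM, between 4000 nM and 40000 nM, with a fair chance that only a limit is again recorded.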

Compound 4, concentration for 50% growth inhibition: > 10000 nM
Compound 4 gave a limit, no number (the forecaster's own chance of this, stated with the estimate: 55%); the middle value does not contradict the limit.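

Compound 1 and compound 4 both end at a limit in this assay, not a number, so no step can be read between them: the limit of > 10000 nM in this assay, at which 2 of the 4 values shown sit.

The compounds shown leave open the size of the change from hydroxy to trifluoromethyl at this place, meta to a large group.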